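Removing the Phenyl from Compound 2

The source may hold more compounds than are shown below. What is called first, only, known or untested is meant among the compounds shown, and "the series" means these compounds.

Measured so far in a functional assay on MCF7 cells (Homo sapiens) for cytotoxicity, read by MTT assay, with a stated time of 72 h; a lower number here means a stronger inhibitor, a higher number a weaker inhibitor:
compound 1, `Cc1c(COC(=O)NCc2ccccc2)cc2n1[C@@H](c1ccccc1)SC2`, gives 2200 nM;
compound 2, `Cc1c(CO)c(CO)c2n1[C@@H](c1ccccc1)SC2`, gives 1000 nM;
compound 3, `Cc1c(CO)cc2n1CSC2`, gives 192000 nM.

Compound 2 has the lowest number of the three and is the strongest inhibitor in this assay: compound 1 stands nearest, with a higher number that lies beyond the usual scatter, and compound 3 stands furthest, with a far higher number. No two of these compounds differ in only one place, so no single step is known. Compound 4, `Cc1c(CO)c(CO)c2n1CSC2`, differs from compound 2 in one place: hydrogen in place of phenyl on a saturated ring carbon. Compound 3 also lacks the phenyl and gives the highest number shown. A large weakening is therefore expected, a 40-fold higher number from compound 2 to compound 4 (1.60 log units; beyond the scatter). Compound 4 is estimated at 40000 nM, within a range from 8000 nM to 200000 nM.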

Compound 4, half-maximal inhibitory concentration: 22600 nM
Beside the measured number, compound 4's estimate is 1.8-fold (0.25 log units) above it, and the stated range covers the measured number.
By their numbers in this assay, from the lowest: compound 2; then compound 1; then compound 4; then compound 3.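

In this assay, the phenyl on the saturated ring carbon now has a step of its own: hydrogen in its place gives a 23-fold higher number from compound 2 to compound 4 (1.35 log units; beyond the scatter), a large weakening. Without the phenyl, the hydroxymethyl on an aromatic carbon also counts, with a modest strengthening of an 8.5-fold lower number from compound 3 to compound 4 (0.93 log units; beyond the scatter). Nothing available explains either step. The compounds shown leave open whether a methyl or a cyclohexyl on that saturated ring carbon would keep the number of compound 2, and whether an amine could replace the hydroxymethyl.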